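This account rests on a few compounds, and the source may have more. Where it says the series, first, only, none or still open, it means among the compounds named here.

Measured in a functional assay on MKN-45 cells (Homo sapiens) for cytotoxicity; a higher number here means a weaker inhibitor, a lower number a stronger inhibitor:

Compound 1 `COc1ccc(S(=O)(=O)N2CCc3cccc(NC(=O)c4ccc(F)cc4)c32)cc1` gives 45 nM
Compound 2 `COc1ccc(S(=O)(=O)N2CCc3cccc(NS(=O)(=O)c4ccccc4)c32)cc1` gives 562 nM
Compound 3 `COc1ccc(S(=O)(=O)N2CCc3cccc(NC(=O)c4ccco4)c32)cc1` gives 10.7 nM

Compound 3 is the strongest of the three, with 10.7 nM. Its lead over the others is beyond the scatter in both cases: a 4.2-fold lower number from compound 1 to compound 3 (0.62 log units; beyond the scatter), and a 53-fold lower number from compound 2 to compound 3 (1.72 log units; beyond the scatter).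

The next compound, compound 4 `COc1ccc(S(=O)(=O)N2CCc3cccc(NC(=O)c4ccc(C#N)cc4)c32)cc1`, keeps the shared core and the amide but places 4-cyanophenyl in place of furan-2-yl on a carbonyl carbon.

The most relevant evidence is the exchange between 4-fluorophenyl and furan-2-yl on that same carbonyl carbon, already given as a 4.2-fold lower number from compound 1 to compound 3 (0.62 log units; beyond the scatter). Read in reverse, it suggests that a return to a substituted phenyl should raise the number by a modest step in this assay. The two larger steps, a 12-fold higher number from compound 1 to compound 2 (1.10 log units; beyond the scatter) and a 53-fold lower number from compound 2 to compound 3 (1.72 log units; beyond the scatter), involve phenylsulfonyl and so bear on the present change only weakly. Within the data shown here, no measured compound carries 4-cyanophenyl, so the comparison with 4-fluorophenyl remains uncertain.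

The expected change is a 3.7-fold higher number from compound 3 to compound 4 (0.57 log units; beyond the scatter). Compound 4 is estimated at 40 nM, with an expected range of 13 nM to 130 nM.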

Compound 4, half-maximal inhibitory concentration: 89 nM
Estimate against measurement, compound 4: 2.2-fold (0.35 log units) below, within the range that was stated.
By their numbers in this assay, from the lowest: compound 3; then compounds 1 and 4 (each within the scatter of the next); then compound 2.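

In this assay, 4-cyanophenyl in place of furan-2-yl on the carbonyl carbon gives an 8.3-fold higher number from compound 3 to compound 4 (0.92 log units; beyond the scatter) and so extends the advantage of furan-2-yl, until now seen only against 4-fluorophenyl, to a second substituted phenyl group. Cyano in place of fluoro on the aromatic carbon gives a 2.0-fold higher number from compound 1 to compound 4 (0.30 log units; within the scatter) and leaves these two substituted phenyl groups unseparated in this assay. The step from the sulfonamide to the new amide, (4-cyanophenyl)carbonyl in place of phenylsulfonyl on the nitrogen, gives a 6.3-fold lower number from compound 2 to compound 4 (0.80 log units; beyond the scatter) and shows that an amide bearing a phenyl ring with a nitrile also keeps a clear margin over compound 2, as the other two amides do.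

Nothing among the data shown accounts for the differences among these groups. As far as these compounds go, it remains open whether the advantage belongs to furan-2-yl alone or extends to other five-membered rings such as thiophen-2-yl, and whether a phenyl ring carrying an amine or a carboxylic acid would stay with compound 1 and compound 4 or move towards compound 3.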